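The source may report more compounds than this note shows. Statements on the series, on what has been measured and on what is new or still open speak of the compounds shown alone.

Compound 1 `N#C/C(=C\c1c[nH]c2cc(F)ccc12)C(=O)c1c[nH]c2ccccc12` and compound 2 `N#C/C(=C\c1c[nH]c2ccccc12)C(=O)c1c[nH]c2ccccc12` differ by hydrogen in place of fluoro on an aromatic carbon. In a functional assay on PC-3 cells (Homo sapiens) for cytotoxicity, read by WST assay, with a stated time of 24 h (on this read-out lower numbers stand for stronger inhibition and higher numbers for weaker inhibition), compound 1 gives only a limit, > 50000 nM. Compound 2 likewise gives only a limit in this assay, namely > 50000 nM. The step that the two limits leave unreadable from compound 1 to compound 2 cannot be read because the limit of > 50000 nM in this assay, at which 3 of the 3 values shown sit, holds both values. Compound 3 `COc1ccc(Cn2cc(/C=C(\C#N)C(=O)c3c[nH]c4cc(F)ccc34)c3ccccc32)cc1` carries the same fluoro as compound 1; the difference between the two cores is not broken down here. In this assay compound 3 also gives only a limit, > 50000 nM. Compound 4 `COc1ccc(Cn2cc(/C=C(\C#N)C(=O)c3c[nH]c4ccccc34)c3ccccc32)cc1` is related to compound 3 by hydrogen in place of fluoro on an aromatic carbon, the same change as between compound 1 and compound 2. Since that earlier step is unreadable and every value sits at the limit of > 50000 nM in this assay, at which 3 of the 3 values shown sit, compound 4 is expected to stay at the limit, with a step that the limit leaves unreadable from compound 3 to compound 4. Compound 4 is therefore estimated at 60000 nM, between 20000 nM and 200000 nM.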

Compound 4, half-maximal inhibitory concentration: > 50000 nM
Compound 4: a limit, no number; the forecaster's own chance of this, stated with the estimate: 85%; the middle value lies beyond the limit too.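

Neither step, from compound 3 to compound 4 or from compound 2 to compound 4, can be read, because all the values are limits rather than numbers: the limit of > 50000 nM in this assay, at which 4 of the 4 values shown sit. In this assay the compounds shown leave open whether fluoro or 4-methoxybenzyl makes any difference.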